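From 4-methylphenyl to methyl on the sulfonyl sulfur

This account rests on a few compounds, and the source may have more. Where it says the series, first, only, none or still open, it means among the compounds named here.

Going by the values given here, compound 1 `NCc1ccc(O)c2ccccc12` and compound 2 `Cc1ccc(S(=O)(=O)Nc2ccc(O)c3ccccc23)cc1` are the only two compounds measured so far. In a functional assay, with a stated time of 15 min (a lower number here means that less compound is needed, a higher number that more compound is needed for the effect), compound 1 gives 260000 nM. Compound 2 gives 16000 nM, the lower of the two numbers, and the gap between them lies beyond the scatter. Compound 3 `CS(=O)(=O)Nc1ccc(O)c2ccccc12` carries methyl in place of 4-methylphenyl on a sulfonyl sulfur. Among the compounds with values here, no measured pair shows this change on its own, so the expectation is uncertain. In this assay a move to a higher number is expected, with an estimated step of a 3.1-fold higher number from compound 2 to compound 3 (0.49 log units; beyond the scatter). The estimate for compound 3 is 50000 nM, with an expected range from 14000 nM to 180000 nM.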

Compound 3, half-maximal effective concentration: 18000 nM
For compound 3 the middle estimate is 2.8-fold (0.44 log units) above the measured one, within the range that was stated.
By their numbers in this assay, from the lowest: compounds 2 and 3 (each within the scatter of the next); then compound 1.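

In this assay, the step of a 1.1-fold higher number from compound 2 to compound 3 (0.05 log units; within the scatter) shows that on the sulfonyl sulfur, methyl and 4-methylphenyl cannot be told apart, so in this pair the six-membered aromatic ring is not required for the number reached. The large step of a 14-fold lower number from compound 1 to compound 3 (1.16 log units; beyond the scatter) comes with methanesulfonamido in place of aminomethyl on an aromatic carbon, and it now rests on a group with no aromatic ring of its own. Nothing available explains either step. Still open, going by these compounds, is how a longer chain, such as propyl, or an amine on the sulfonyl sulfur would read in this assay.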